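Hydroxamate series: removing the aryl methyl

The compounds below may be only part of what the source reports. "The series", "measured", "known", "first", "only" and "open" are said of these compounds alone.

Compound 1 `COc1cc2c(Oc3ccc(NC(=O)c4nn(-c5ccccc5C)cc(C)c4=O)cc3F)ccnc2cc1OCCCC(=O)NO` and compound 3 `COc1cc2c(Oc3ccc(NC(=O)c4nn(-c5ccccc5)cc(C)c4=O)cc3F)ccnc2cc1OCCCC(=O)NO` share one core and differ only where (hydrogen in place of methyl on an aromatic carbon). In a functional assay on A549 cells (Homo sapiens) for inhibition, read by MTT assay, with a stated time of 72 h (on this read-out lower numbers stand for stronger inhibition and higher numbers for weaker inhibition), compound 1 gives 2090 nM and compound 3 gives 1900 nM; the step is a 1.1-fold lower number from compound 1 to compound 3 (0.04 log units; within the scatter). Compound 2 `COc1cc2c(Oc3ccc(NC(=O)c4nn(-c5ccccc5C)cc(C)c4=O)cc3)ccnc2cc1OCCCCCCC(=O)NO` carries a different core, and the difference between the cores of compound 1 and compound 2 is not broken down here. In this assay compound 2 gives 3130 nM, and this value lies within the scatter of those of compound 1 and compound 3, so no order among the three can be drawn.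

Compound 4 `COc1cc2c(Oc3ccc(NC(=O)c4nn(-c5ccccc5)cc(C)c4=O)cc3)ccnc2cc1OCCCCCCC(=O)NO` stands to compound 2 as compound 3 stands to compound 1: hydrogen in place of methyl on an aromatic carbon. The place of the change reads the same in both pairs, so it is the same change, not merely the same kind. Because the measured step was only a 1.1-fold lower number from compound 1 to compound 3 (0.04 log units; within the scatter), the expectation for compound 4 is a step of the same small size, a 1.1-fold lower number from compound 2 to compound 4 (0.05 log units; within the scatter). On that basis compound 4 is estimated at 2800 nM in this assay, with a range from 1500 nM to 5200 nM. The estimate rests on a single measured pair and on the value of compound 2.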

Compound 4, half-maximal inhibitory concentration: 420 nM
Beside the measured number, compound 4's estimate is 6.7-fold (0.82 log units) above it, outside the stated range (below it).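

In this assay, replacing 2-methylphenyl with phenyl gives a 7.5-fold lower number from compound 2 to compound 4 (0.87 log units; beyond the scatter), a clear gain on the core of compound 2. The size of this step does not transfer between the two cores, so a step measured on one core is a poor guide to the other: the same change on two cores in this assay, a 1.1-fold lower number (0.04 log units; within the scatter) from compound 1 to compound 3 and a 7.5-fold lower number (0.87 log units; beyond the scatter) from compound 2 to compound 4, 6.8-fold (0.83 log units) apart, beyond the scatter of two such steps. The two pairs show that the outcome of this change depends on the core, but they do not show which difference between the cores is responsible, and two pairs set no rule for the wider series.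

Open, on these data alone, is which core feature goes with the gap: a compound joining the aromatic fluorine of compound 1 to the longer chain of compound 2 would help separate the two. Also open, as far as these compounds go, is how a chlorine or a methoxy group in place of the methyl would read on each core, and whether either would follow the step seen with hydrogen.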